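Swapping a Hydroxyphenyl Position on an Inactive Scaffold

The compounds below may be only part of what the source reports. "The series", "measured", "known", "first", "only" and "open" are said of these compounds alone.

Of the compounds shown here, three sharing one core have been tested in a functional assay on HeLa cells (Homo sapiens) for inhibition; a lower number here means a stronger inhibitor, a higher number a weaker inhibitor. Compound 1 `Oc1ccccc1-c1cc(-c2cccc(F)c2)cc(-c2ccccc2O)n1` gives > 50000 nM, which is a limit of the assay rather than a number. Compound 2 `Oc1cccc(-c2cc(-c3ccc(F)cc3)cc(-c3ccccc3O)n2)c1` likewise gives > 50000 nM, again only a limit. Compound 3 `Oc1ccccc1-c1cc(-c2ccc(C(F)(F)F)cc2)cc(-c2ccccc2O)n1` gives > 50000 nM, once more a limit. Compound 3 therefore stands at the same limit as the other two, and the step that the two limits leave unreadable from compound 1 to compound 3 cannot be read, because the limit of > 50000 nM in this assay, at which 3 of the 3 values shown sit, holds all three values at the same edge.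

Compound 4 `Oc1cccc(-c2cc(-c3ccc(C(F)(F)F)cc3)cc(-c3ccccc3O)n2)c1` differs from compound 3 by 3-hydroxyphenyl in place of 2-hydroxyphenyl on an aromatic carbon. Going by the values given here, no measured step speaks to this change directly; compound 2, which also carries a 3-hydroxyphenyl group, shows only a limit. With every neighbour sitting at the limit, no movement beyond the scatter is expected in this assay, so the step of a number no higher from compound 3 to compound 4 (the limit leaves the size open) is estimated as essentially none. Compound 4 is accordingly expected to give about 50000 nM, within 20000 nM to 150000 nM, most likely reported again only as a limit.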

Compound 4, half-maximal inhibitory concentration: > 50000 nM
Compound 4 gave a limit, no number (the forecaster's own chance of this, stated with the estimate: 85%); the middle value sits exactly at the limit.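

Neither the step from compound 3 to compound 4 nor the step from compound 2 to compound 4 can be read, because every result is a limit rather than a number: the limit of > 50000 nM in this assay, at which 4 of the 4 values shown sit. In this assay the compounds shown leave open which changes to the shared core, if any, would give a readable inhibition value.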